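Urea series: a ring swap on the methylene carbon

The compounds below may be only part of what the source reports. "The series", "measured", "known", "first", "only" and "open" are said of these compounds alone.

Measured so far:
compound 1 `O=C(Nc1ccccc1)N(Cc1ccccn1)n1cnnc1` — 24900 nM
compound 2 `O=C(NC1CCCCC1)N(Cc1ccccn1)n1cnnc1` — > 50000 nM

Going by the values given here, in a functional assay on A549 cells (Homo sapiens) for cytotoxicity, read by MTT assay, with a stated time of 48 h (a higher number here means a weaker inhibitor, a lower number a stronger inhibitor), compound 1 gives 24900 nM, the only full number in the set. Compound 2 reaches only the limit > 50000 nM in this assay, which is a limit and not a number, as the limit of > 50000 nM in this assay, at which 1 of the 2 values shown sits, records. Among the compounds with values here, the single measured step, an at least 2.0-fold higher number from compound 1 to compound 2 (0.30 log units; that floor lies within the scatter), sits on the amide-type nitrogen and says little about the carbon side of the urea.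

Compound 3 `N#Cc1ccc(CN(C(=O)Nc2ccccc2)n2cnnc2)cc1` differs from compound 1 by 4-cyanophenyl in place of pyridin-2-yl on a saturated chain carbon bound to an amide-type nitrogen. Within the data shown here, no measured step touches a saturated chain carbon bound to an amide-type nitrogen, so the series offers no direction for this change; no shift beyond the scatter is assumed, with wide uncertainty toward the limit. For compound 3 the expected value in this assay is 30000 nM, within 10000 nM to 90000 nM. This expectation for compound 3 amounts to a step of a 1.2-fold higher number from compound 1 to compound 3 (0.08 log units; within the scatter).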

Compound 3, half-maximal inhibitory concentration: > 50000 nM
Compound 3 gave a limit, no number; the forecaster's own chance of this, stated with the estimate: 35%; at least 1.6-fold (0.22 log units) between middle value and limit.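

Going by these compounds alone, this is the first reading at the saturated chain carbon bound to an amide-type nitrogen: in this assay, 4-cyanophenyl in place of pyridin-2-yl gives an at least 2.0-fold higher number from compound 1 to compound 3 (0.30 log units; that floor lies within the scatter). The step rests on a limit and not on a number, so it sets only a floor, and no loss beyond the scatter can be claimed; what it does show is that this swap brings no readable gain at this position. Changes at two different places now both end at the same limit: the limit of > 50000 nM in this assay, at which 2 of the 3 values shown sit.

Within the data shown here, how far compound 3 lies past its limit stays open, and with compound 1 as the only full number, no trend across rings at this carbon can be drawn. Also open, as far as these compounds go, is whether a carboxylic acid or an aminomethyl group in place of the nitrile would bring the value back within range.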